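Swapping Chloro for Methoxy on a Shared Core

The source may hold more compounds than are shown below. What is called first, only, known or untested is meant among the compounds shown, and "the series" means these compounds.

Of the compounds shown here, three built on one shared core have been measured in a functional assay on SK-MEL-28 cells (Homo sapiens) for inhibition, read by sulforhodamine B assay, with a stated time of 48 h; a lower number here means a stronger inhibitor of growth, a higher number a weaker inhibitor of growth. Compound 1 `N=C(N)c1ccc(-c2ccc(-c3cc(Cl)cc(Cl)c3)s2)cc1` gives 1710 nM. Compound 2 `N=C(N)c1ccc(-c2ccc(-c3ccc(Cl)cc3)s2)cc1F` gives 205 nM in this assay. Compound 3 `COc1cc(OC)cc(-c2ccc(-c3ccc(C(=N)N)c(F)c3)s2)c1` gives 176 nM in this assay. Among these three numbers compound 2 stands second highest; its nearest neighbour is compound 3, whose value lies within the scatter of repeated measurements, and its furthest is compound 1, which lies beyond the scatter and is thus the weaker inhibitor of growth of the two.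

The unmeasured compound 4 `COc1ccc(-c2ccc(-c3ccc(C(=N)N)c(F)c3)s2)cc1` differs from compound 2 in one place: methoxy in place of chloro on an aromatic carbon. Among the compounds with values here, no pair of measured compounds differing in a single place is available, so the size of this step cannot be read from a measured step. Compound 3 carries methoxy rather than chloro and gives 176 nM, while compound 2 gives 205 nM; these two numbers lie within the scatter of each other, which suggests that replacing chloro by methoxy need not move the number far. Compound 4 is therefore expected to stay close to compound 2, with a step of a 1.3-fold higher number from compound 2 to compound 4 (0.10 log units; within the scatter) that is expected to lie within the scatter or a little toward a weaker inhibitor. The estimate for compound 4 is 260 nM, with a range from 110 nM to 650 nM.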

Compound 4, concentration for 50% growth inhibition: 2310 nM
The estimate for compound 4 lay 8.9-fold (0.95 log units) below the measured number; measured number above the stated range.
By their numbers in this assay, from the lowest: compounds 3 and 2 (each within the scatter of the next); then compounds 1 and 4 (each within the scatter of the next).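

In this assay, methoxy in place of chloro on an aromatic carbon, para to a large group, proves to be a large change: an 11-fold higher number from compound 2 to compound 4 (1.05 log units; beyond the scatter), beyond the scatter. Within the data shown here, this is the first step that can be read between two measured compounds differing in one place, and it shows that this position does not treat chloro and methoxy as interchangeable, which the earlier compounds, with no such pair among them, could not show. Nothing available on these compounds accounts for the size of the step.

With only chloro and methoxy shown at this position, it remains open whether the higher number belongs to methoxy in particular or follows any replacement of chloro, and a methyl, a hydroxyl, an amine or a bare hydrogen at the same carbon would help to separate the two. On these data alone, it also remains open whether the step keeps its size without the fluoro group that compound 2 and compound 4 share, or with the same change made elsewhere on that aromatic ring.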